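Isopropyl in Place of Methyl on the Saturated Chain

A few compounds are considered here, and "the series" means these few. Any claim that something is new, unique, unknown or untested is made for them only; others in the source may bear on it.

In a physicochemical assay for solubility, with a stated time of 24 h, tested at 30 mg/mL (a lower number here means a less soluble compound, a higher number a more soluble compound), compound 1 `CC(CCCCC(=O)NO)Nc1c(Nc2ccccc2)c(=O)c1=O` gives 46000000 nM, compound 2 `Cc1ccc(Nc2c(NC(C)CCCCC(=O)NO)c(=O)c2=O)cc1` gives 4900000 nM and compound 3 `CC(CCCCC(=O)NO)Nc1c(Nc2ccc(C(F)(F)F)cc2)c(=O)c1=O` gives 20000000 nM. Compound 3 therefore holds the second highest of the three numbers, under compound 1 and over compound 2. Compound 4 `CC(C)C(CCCCC(=O)NO)Nc1c(Nc2ccc(C(F)(F)F)cc2)c(=O)c1=O` keeps everything else in compound 3 but has isopropyl in place of methyl on a saturated chain carbon bound to a nitrogen on an aromatic ring and a saturated chain carbon. Among the measured compounds shown here, no measured step touches this chain, so the evidence is indirect. The measured changes all lie on an aromatic carbon: a 9.4-fold lower number from compound 1 to compound 2 (0.97 log units; beyond the scatter), a 2.3-fold lower number from compound 1 to compound 3 (0.36 log units; beyond the scatter) and a 4.1-fold higher number from compound 2 to compound 3 (0.61 log units; beyond the scatter). Both substitutions on compound 1 lowered the number, while the last step went the other way, so the direction is only tentatively read across. A modest fall is expected, of a size within the range of these steps, and the expected step is a 2.2-fold lower number from compound 3 to compound 4 (0.35 log units; beyond the scatter). For compound 4 the estimated value is 9000000 nM, with an expected range of 2500000 nM to 30000000 nM.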

Compound 4, solubility: 6300000 nM
For compound 4 the middle estimate is 1.4-fold (0.15 log units) above the measured one, within the range that was stated.
By their numbers in this assay, from the lowest: compounds 2 and 4 (each within the scatter of the next); then compound 3; then compound 1.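

Compound 4 supplies the first measured step away from an aromatic carbon, and in this assay isopropyl in place of methyl on this saturated chain carbon gives a 3.2-fold lower number from compound 3 to compound 4 (0.50 log units; beyond the scatter) and so shows that the number responds to this place as well as to the aromatic substituent. The size of that step lies within the span set by a 2.3-fold lower number from compound 1 to compound 3 (0.36 log units; beyond the scatter) and a 9.4-fold lower number from compound 1 to compound 2 (0.97 log units; beyond the scatter), so this chain change moves the number on a scale comparable to the two aromatic substitutions. Nothing available explains the fall.

Still open, on these data alone, is how an ethyl group or an amine on this chain carbon would compare with methyl and isopropyl. The compounds shown also leave open whether isopropyl in place of methyl would give a similar step on compound 1 or compound 2.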